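Swapping the aryl group on the piperazine: a nitro variant

The source may report more compounds than this note shows. Statements on the series, on what has been measured and on what is new or still open speak of the compounds shown alone.

Measured compounds:
- compound 1, `Cc1c(C#N)c(-c2ccccc2)nn1CCCN1CCN(c2ccc(F)cc2)CC1`: 28%
- compound 2, `Cc1c(C#N)c(-c2ccccc2)nn1CCCN1CCN(c2cccc(Cl)c2)CC1`: 0%
- compound 3, `COc1cccc(N2CCN(CCCn3nc(-c4ccccc4)c(C#N)c3C)CC2)c1`: 21%

All three share a core and differ only in the aryl group on the ring nitrogen. In a functional assay on the whole organism (Abdomen, strain Swiss) for inhibition, with Mus musculus as the target, with stated times of 30 min, 10 min and 5 min, at a dose of 20 mg/kg by the oral route (a lower number here means a weaker effect, a higher number a stronger effect of the compound at the dose given), compound 3 gives 21%, the second highest of the three numbers; its gap to compound 1 is within the scatter, a number 7 percentage points lower from compound 1 to compound 3 (within the scatter), while its gap to compound 2 is beyond it, a number 21 percentage points higher from compound 2 to compound 3 (beyond the scatter).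

Compound 4, `Cc1c(C#N)c(-c2ccccc2)nn1CCCN1CCN(c2ccc([N+](=O)[O-])cc2)CC1`, has not yet been measured. Its change from compound 3 is 4-nitrophenyl in place of 3-methoxyphenyl on an amine nitrogen in a ring. Among the compounds with values here, no measured step swaps in a nitrophenyl group, so the two steps that end at compound 3 are the only guide: one change of this aryl group left the number about unchanged, the other moved it modestly. A step of similar modest size in either direction, or none beyond the scatter, seems plausible in this assay. Compound 4 is therefore expected to give about 18%, with a range from 0% to 42%, which corresponds to an expected step of a number 3 percentage points lower from compound 3 to compound 4 (within the scatter).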

Compound 4, a percentage reported as inhibition, in the whole organism at one dose (the size of the read-out at that dose, not a potency): 21%
Beside the measured number, compound 4's estimate is 3 percentage points below it, and the stated range covers the measured number.
By their numbers in this assay, from the lowest: compound 2; then compounds 3, 4 and 1 (each within the scatter of the next).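

In this assay, the result is no change at the digits printed from compound 3 to compound 4 (within the scatter), and likewise a number 7 percentage points lower from compound 1 to compound 4 (within the scatter), so 4-nitrophenyl, 3-methoxyphenyl and 4-fluorophenyl cannot be told apart on this amine nitrogen in a ring. The 3-chlorophenyl group of compound 2 now stands alone against three different aryl groups, with a number 21 percentage points higher from compound 2 to compound 4 (beyond the scatter), which means that a large swap of the aryl group here need not shift the number at all. Within the data shown here, nothing measured alongside these numbers explains why only that one group stands apart.

Going by these compounds, whether the low number of compound 2 comes from the chlorine itself or from where it sits on the ring remains open. Also open, on these data alone, is what a 4-chlorophenyl group, a plain phenyl group or a pyridine ring would give here.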